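Lengthening the Hydroxyalkyl Chain from Compound 2 to Compound 3

A few compounds are considered here, and "the series" means these few. Any claim that something is new, unique, unknown or untested is made for them only; others in the source may bear on it.

Of the compounds shown here, two sharing one core have been measured in an ADME assay on PANC-1 cells (Homo sapiens) for cytotoxicity, read by sulforhodamine B assay, with a stated time of 48 h, tested at 10 uM; on this read-out higher numbers stand for more inhibition at the one concentration tested (going by the name of the read-out) and lower numbers for less inhibition. Compound 2 `COc1nc2ccc(Br)cc2cc1C(c1ccccc1)n1cc(CCO)nn1` gives 19.8%, and compound 1 `COc1nc2ccc(Br)cc2cc1C(c1ccccc1)n1cc(-c2ccc(OC(F)(F)F)cc2)nn1` gives 11.7%. Among the measured compounds shown here, the only measured step, a number 8.1 percentage points higher from compound 1 to compound 2 (within the scatter), lies within the scatter, so on these two numbers compound 2 cannot be set apart from compound 1; both sit at the low end of the read-out.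

Compound 3 `COc1nc2ccc(Br)cc2cc1C(c1ccccc1)n1cc(CCCCCO)nn1` differs from compound 2 by 3-hydroxypropyl in place of hydroxy on a saturated chain carbon, two bonds along the chain from an aromatic carbon. For the measured compounds named here, no measured step bears on a change of this kind: the one step available replaces an aromatic group by 2-hydroxyethyl and shifts the read-out only within the scatter. The measured pair therefore gives no ground for expecting a move in either direction, and the expected step is one that stays within the scatter: a number 1.8 percentage points lower from compound 2 to compound 3 (within the scatter). Compound 3 is accordingly estimated at 18%, with a range from 5% to 32%.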

Compound 3, a percentage reported as inhibition, at one concentration (the size of the read-out at that concentration, not a potency): 19.6%
Compound 3: middle estimate off by 1.6 percentage points, on the low side; measured number inside the range.
By their numbers in this assay, from the lowest: compounds 1, 3 and 2 (each within the scatter of the next).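

Among the compounds shown here, the longer chain opens up a comparison the earlier compounds did not offer, a change within the hydroxyalkyl chain itself: in this assay, 3-hydroxypropyl in place of hydroxy on a saturated chain carbon, two bonds along the chain from an aromatic carbon, gives a number 0.2 percentage points lower from compound 2 to compound 3 (within the scatter) and so leaves the read-out indistinguishable between 2-hydroxyethyl and 5-hydroxypentyl. Set against the 4-(trifluoromethoxy)phenyl group on the aromatic carbon, the longer chain gives a number 7.9 percentage points higher from compound 1 to compound 3 (within the scatter) and so, like the shorter chain, cannot be separated from that aromatic group, which means that all three groups at this position remain alike on this read-out. No supporting measurement is available to account for this flat picture at this position.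

Going by these compounds, it remains open whether a terminal amine or carboxylic acid in place of the hydroxy, or a chain longer than 5-hydroxypentyl, would move the read-out beyond the usual scatter. Also open, on these data alone, is whether the three compounds would separate when tested at other concentrations, as the single concentration used here gives the size of the read-out and not a potency.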